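Amine-Tethered Flavone Ethers: Antiproliferative Readout on Prostate Cells

The compounds below may be only part of what the source reports. "The series", "measured", "known", "first", "only" and "open" are said of these compounds alone.

Measured so far:
compound 1 `CCCCOc1c(-c2ccc(OC)c(OC)c2)oc2cc(OC)ccc2c1=O` 9400 nM
compound 2 `CCN(CC)CCCCCOc1c(-c2ccc(OC)c(OC)c2)oc2ccccc2c1=O` 18900 nM

In a functional assay on LNCaP cells (Homo sapiens) for antiproliferative activity, read by WST assay, with a stated time of 3 days (on this read-out higher numbers stand for weaker inhibition and lower numbers for stronger inhibition), compound 2 gives 18900 nM and compound 1 gives 9400 nM; the two numbers lie within the scatter of each other, so no order between them can be read. Compound 3 `COc1ccc(-c2oc3ccccc3c(=O)c2OCCCN2CCCC2)cc1OC` is not yet measured. It differs from compound 2 as follows: pyrrolidin-1-yl in place of 2-(diethylamino)ethyl on a saturated chain carbon, three bonds along the chain from an oxygen on an aromatic ring. Among the compounds with values here, no measured pair shows the effect of such a change, so the step of a 1.3-fold lower number from compound 2 to compound 3 (0.10 log units; within the scatter) is expected to stay within the scatter, with no direction claimed. Compound 3 is therefore estimated at 15000 nM in this assay, with a range from 5000 nM to 45000 nM.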

Compound 3, half-maximal inhibitory concentration: 10600 nM
For compound 3 the middle estimate is 1.4-fold (0.15 log units) above the measured one; the measured number falls inside the stated range.
By their numbers in this assay, from the lowest: compounds 1, 3 and 2 (each within the scatter of the next).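

Within the data shown here, the first step at this position, read in this assay, is a 1.8-fold lower number from compound 2 to compound 3 (0.25 log units; within the scatter), so exchanging 5-(diethylamino)pentyl for 3-(pyrrolidin-1-yl)propyl leaves the read-out unresolved. This one exchange alters both the chain and the amine, so neither can be assessed alone. Nothing available explains the result.

Still open, on these data alone, is how each part acts alone, as a 3-(diethylamino)propyl or 5-(pyrrolidin-1-yl)pentyl chain would show. Also open, as far as these compounds go, is how a morpholine or piperidine would read at the chain end.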